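Swapping the aryl on the carbonyl of compound 3

This account rests on a few compounds, and the source may have more. Where it says the series, first, only, none or still open, it means among the compounds named here.

The study follows three compounds that share one core and differ in the group carried on the carbonyl carbon and in the azole on the distal phenyl. Compound 2 `CC(=O)N1N=C(c2ccc(-n3ccnc3)cc2)CC1c1ccc(N(C)C)cc1` gives 5% in a functional assay on MDA-MB-231 cells (Homo sapiens) for inhibition, read by sulforhodamine B assay, tested at 10 uM; on this read-out lower numbers stand for less inhibition and higher numbers for more inhibition at the one concentration tested (going by the name of the read-out). Compound 3 `CN(C)c1ccc(C2CC(c3ccc(-n4ccnc4)cc3)=NN2C(=O)c2ccc(F)cc2)cc1` gives 9.4%, and the step of a number 4.4 percentage points higher from compound 2 to compound 3 (within the scatter) does not leave the scatter. Compound 1 `CN(C)c1ccc(C2CC(c3ccc(-n4cncn4)cc3)=NN2C(=O)c2cc(Cl)cc(Cl)c2)cc1` gives 9.4%, a number level with compound 3 at the digits shown; since compound 1 and compound 3 differ in two places, their values are only compared, not read as a step. Among the compounds with values here, compound 3 thus sits at the top of the three, but no step separates it from compound 1 beyond the scatter.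

Compound 4 `CN(C)c1ccc(C2CC(c3ccc(-n4ccnc4)cc3)=NN2C(=O)c2cc(Cl)cc(Cl)c2)cc1` arises from compound 3 by 3,5-dichlorophenyl in place of 4-fluorophenyl on a carbonyl carbon. Within the data shown here, the only measured step at this position, the one from compound 2 to compound 3, stayed within the scatter, and compound 1, which also carries the 3,5-dichlorophenyl, shows a value no different from compound 3. The step of a number 0.4 percentage points lower from compound 3 to compound 4 (within the scatter) is therefore expected to stay within the scatter. Compound 4 is estimated at 9%, between 0% and 22%.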

Compound 4, a percentage reported as inhibition, at one concentration (the size of the read-out at that concentration, not a potency): 48.8%
The estimate for compound 4 lay 39.8 percentage points below the measured number; the measured number lies above the stated range.
By their numbers in this assay, from the lowest: compounds 2, 1 and 3 (each within the scatter of the next); then compound 4.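

Replacing the group on the carbonyl carbon can shift the number strongly: in this assay there is a number 39.4 percentage points higher from compound 3 to compound 4 (beyond the scatter) for the 4-fluorophenyl exchange and a number 43.8 percentage points higher from compound 2 to compound 4 (beyond the scatter) for the exchange from methyl. The earlier step at this position, a number 4.4 percentage points higher from compound 2 to compound 3 (within the scatter) and thus small, gave no sign of such a change. The azole matters too, with a number 39.4 percentage points higher from compound 1 to compound 4 (beyond the scatter) when 1H-imidazol-1-yl replaces 1H-1,2,4-triazol-1-yl, so among these compounds the high number appears only where 3,5-dichlorophenyl and 1H-imidazol-1-yl occur together.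

The compounds shown leave open whether a 3-chlorophenyl or a 3,5-dimethylphenyl on the carbonyl carbon would hold this number. No measurement at hand explains the result.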